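The source may report more compounds than this note shows. Statements on the series, on what has been measured and on what is new or still open speak of the compounds shown alone.

The series rests on a shared core and differs in the aryl group on a carbon with a double bond to nitrogen. In a functional assay on MKN-45 cells (Homo sapiens) for cytotoxicity, read by MTT assay, with a stated time of 72 h (on this read-out lower numbers stand for stronger inhibition and higher numbers for weaker inhibition), compound 2 `CN(C)CCn1cnnc1-c1cc(Oc2ccc(NC(=O)N/N=C/c3ccccc3O[N+](=O)[O-])cc2F)ccn1` gives 1020 nM, the lowest of the two numbers that this assay has so far yielded. Compound 1 `CN(C)CCn1cnnc1-c1cc(Oc2ccc(NC(=O)N/N=C/c3cc(C(C)(C)C)cc(C(C)(C)C)c3O)cc2F)ccn1` gives 3300 nM in this assay, and that gap to compound 2 lies beyond the usual scatter. Compound 3 `Cn1ncnc1-c1cc(Oc2ccc(NC(=O)N/N=C/c3ccccc3)cc2F)ccn1` reaches only a limit of this assay, > 100000 nM, as recorded in the limit of > 100000 nM in this assay, at which 1 of the 3 values shown sits.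

Compound 4 `CN(C)CCn1cnnc1-c1cc(Oc2ccc(NC(=O)N/N=C/c3ccc(O)cc3)cc2F)ccn1` has not yet been measured. It differs from compound 2 in a single place: 4-hydroxyphenyl in place of 2-(nitrooxy)phenyl on a carbon with a double bond to nitrogen. Going by the values given here, no pair of measured compounds separated by one change is available, so the size of this step is open. A loss is expected rather than a gain, because compound 1, the other hydroxyphenyl-bearing member, gives 3300 nM in this assay. The estimate for compound 4 in this assay is 5000 nM, expected to fall between 1500 nM and 30000 nM. This corresponds to an expected step of a 4.9-fold higher number from compound 2 to compound 4 (0.69 log units; beyond the scatter), which would be beyond the scatter but would still leave compound 4 far from the limit reached by compound 3.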

Compound 4, half-maximal inhibitory concentration: 820 nM
Compound 4: the middle estimate sits 6.1-fold (0.79 log units) above what was measured; the measured number lies below the stated range.
By their numbers in this assay, from the lowest: compounds 4 and 2 (each within the scatter of the next); then compound 1. At a limit, above all of these: compound 3.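

In this assay, putting 4-hydroxyphenyl in place of 2-(nitrooxy)phenyl on a carbon with a double bond to nitrogen gives a 1.2-fold lower number from compound 2 to compound 4 (0.09 log units; within the scatter), so compound 2 and compound 4 cannot be told apart on this read-out. Going by these compounds alone, this is the first step that can be read across a single change, and it gives this position a measured size: an exchange of 2-(nitrooxy)phenyl, with 10 heavy atoms and 0 hydrogen-bond donors, for 4-hydroxyphenyl, with 7 heavy atoms and 1 hydrogen-bond donor, stays within the scatter, so in this pair the nitrooxy group is not needed to hold the number at this level. Nothing measured here says why the two groups read alike.

Going by these compounds, whether an amine or a carboxylic acid on the aryl ring at this place would also leave the number within the scatter stays open. Also open, on these data alone, is how a plain phenyl would read on the core of compound 2, since compound 3 carries that group but differs in more than one place and stands at a limit of the assay.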